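A few compounds are considered here, and "the series" means these few. Any claim that something is new, unique, unknown or untested is made for them only; others in the source may bear on it.

Measured compounds in an ADME assay on the whole organism with Oryza sativa as the target, tested at 1 uM; a lower number here means a stronger effect, a higher number a weaker effect of the compound at the concentration tested:

compound 1, `Cc1cccc(NC(=O)N[C@@H](C)c2ccccc2)c1`, 100%
compound 2, `C[C@H](NC(=O)Nc1cccc(F)c1)c1ccccc1`, 94%
compound 3, `C[C@@H](NC(=O)Nc1ccc(F)cc1F)c1ccccc1`, 100%

Compound 1 and compound 3 stand level at the digits given, together the highest of the three numbers; compound 2 is the only one that sits below them, and the gap is within the scatter. The step of a number 6 percentage points higher from compound 2 to compound 1 (within the scatter) belongs to the change (methyl in place of fluoro on an aromatic carbon), and it is within the scatter, so the change shows no effect that can be told apart from repeat measurement here. The difference between the core of compound 2 and the core of compound 3 is not broken down here.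

Compound 4, `Cc1ccc(NC(=O)N[C@H](C)c2ccccc2)c(F)c1`, is not yet measured in this assay. It arises from compound 3 by methyl in place of fluoro on an aromatic carbon. Among the compounds with values here, this is the same kind of change as the one from compound 2 to compound 1, but the surroundings are not the same: in compound 4 the methyl sits meta to a fluoro group and para to a large group, whereas in compound 1 it sits meta to a large group. The change occurs twice among the compounds shown, once measured.

Within the data shown here, compound 4 is expected to stay level with compound 3, with an estimated step of no change at the digits printed from compound 3 to compound 4 (within the scatter), because the only measured instance of this change, a number 6 percentage points higher from compound 2 to compound 1 (within the scatter), lies within the scatter and compound 3 already gives 100%. The estimate for compound 4 is 100%, between 92% and 106%.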

Compound 4, a percentage reported as activity, at one concentration (the size of the read-out at that concentration, not a potency): 99%
Compound 4: the middle estimate sits 1 percentage points above what was measured, within the range that was stated.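

In this assay, methyl in place of fluoro on an aromatic carbon gives a number 1 percentage points lower from compound 3 to compound 4 (within the scatter), so on the core of compound 3, as on the core of compound 2, the change has no effect that can be told apart from repeat measurement. Within this pair of cores the change carries over without a detectable difference between the two instances: the same change on two cores in this assay, a number 6 percentage points higher (within the scatter) from compound 2 to compound 1 and a number 1 percentage points lower (within the scatter) from compound 3 to compound 4, 7 percentage points apart, within the scatter of two such steps. Within the data shown here, this agreement rests on only two cores, and with compound 3 at 100% and compound 4 at 99% it shows that the swap is silent at the weak end of the read-out, not that it would stay silent on a core with a stronger effect, nor that it would do so with the methyl at some other place on the ring.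

The compounds shown carry only fluoro and methyl on this aromatic ring, so how an amine, a carboxylic acid or a methoxy group would read there remains open. The read-out also stands at a single concentration, which leaves open whether these compounds would differ in a stronger or weaker effect at any other concentration.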